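Fluoro on the urea phenyl across two cores

The source may report more compounds than this note shows. Statements on the series, on what has been measured and on what is new or still open speak of the compounds shown alone.

Compound 1 `CN(C)CCNc1nc(-c2ccc(NC(=O)Nc3ccccc3)cc2)nc2ccsc12` gives 620 nM in a functional assay on HT-29 cells (Homo sapiens) for cytotoxicity, read by MTT assay, with a stated time of 72 h; on this read-out lower numbers stand for stronger inhibition and higher numbers for weaker inhibition. Compound 2 `CN(C)CCNc1nc(-c2ccc(NC(=O)Nc3ccc(F)cc3)cc2)nc2ccsc12` carries fluoro in place of hydrogen on an aromatic carbon relative to compound 1; in this assay compound 2 gives 350 nM, and the step is a 1.8-fold lower number from compound 1 to compound 2 (0.25 log units; within the scatter). Compound 3 `CCN(CC)CCCNc1nc(-c2ccc(NC(=O)Nc3ccccc3)cc2)nc2c(Cl)c(Cl)sc12` rests on a second core; the difference between the two cores is not broken down here. In this assay compound 3 gives 820 nM, a number within the scatter of compound 1 and beyond the scatter of compound 2, whose number lies lower.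

Compound 4 `CCN(CC)CCCNc1nc(-c2ccc(NC(=O)Nc3ccc(F)cc3)cc2)nc2c(Cl)c(Cl)sc12` has not yet been measured. It carries fluoro in place of hydrogen on an aromatic carbon, the same change as that from compound 1 to compound 2, at the same place on the phenylcarbamoyl group. Within the data shown here, only that one earlier instance of the change is on hand, and it fell within the scatter, so the step from compound 3 to compound 4 is expected to be a 1.7-fold lower number from compound 3 to compound 4 (0.24 log units; within the scatter), of a size like the earlier one because of a 1.8-fold lower number from compound 1 to compound 2 (0.25 log units; within the scatter). Compound 4 is therefore estimated at 470 nM in this assay, within a range from 200 nM to 1100 nM.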

Compound 4, half-maximal inhibitory concentration: 350 nM
Compound 4: middle estimate off by 1.3-fold (0.13 log units), on the high side; measured number inside the range.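

In this assay, the change from phenyl to 4-fluorophenyl gives a 2.3-fold lower number from compound 3 to compound 4 (0.37 log units; beyond the scatter), while the earlier instance of the same change gives a 1.8-fold lower number from compound 1 to compound 2 (0.25 log units; within the scatter). Among these compounds, only the newer step lies beyond the scatter, yet the two steps point the same way and cannot be told apart in size: the same change on two cores in this assay, a 1.8-fold lower number (0.25 log units; within the scatter) from compound 1 to compound 2 and a 2.3-fold lower number (0.37 log units; beyond the scatter) from compound 3 to compound 4, 1.3-fold (0.12 log units) apart, within the scatter of two such steps This shows that the change carries over between these two cores with no detectable difference in its size, but it rests on only two pairs, and those pairs differ from each other in both the core and the amine chain, so it shows neither which of these matters nor that the step would hold on any further core.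

The compounds shown leave open whether chloro, methoxy or trifluoromethyl in the same place on the phenyl would give a step like that of fluoro. They also leave open how the change behaves when each amine chain is paired with the other core.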